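This account rests on a few compounds, and the source may have more. Where it says the series, first, only, none or still open, it means among the compounds named here.

Measured so far:
- compound 1 `CC(=O)Nc1nc(-c2cccc(NS(=O)(=O)c3ccc(C#C[Si](C)(C)C)cc3)c2)cs1`: 94.3%
- compound 2 `CCCCCCC#Cc1cccc(S(=O)(=O)Nc2cccc(-c3csc(NC(C)=O)n3)c2)c1`: 56.9%

Of the compounds shown here, two have been tested in a functional assay on A-375 cells (Homo sapiens) for antiproliferative activity, read by trypan blue exclusion, with a stated time of 48 h, tested at 1 uM; a lower number here means a stronger effect, a higher number a weaker effect of the compound at the concentration tested. Compound 2 gives 56.9%, the lower of the two numbers and therefore the stronger effect, while compound 1 gives 94.3%, a gap that lies beyond the usual scatter. Compound 3 `CC(=O)Nc1nc(-c2cccc(NS(=O)(=O)c3cccc(C#C[Si](C)(C)C)c3)c2)cs1` has not yet been measured. It differs from compound 2 in one place: a group of 4 heavy atoms (3 carbon, 1 silicon; no ring) in place of a group of 6 heavy atoms (6 carbon; no ring), on a triple-bonded carbon. Going by the values given here, no step between measured compounds matches this change, so the size of the step can only be guessed. Among the compounds with values here, the one compound that carries a group of the same make-up on a triple-bonded carbon, compound 1, gives 94.3%, a weak effect. On that basis the step is expected to go toward higher numbers, with an estimated change of a number 21.1 percentage points higher from compound 2 to compound 3 (beyond the scatter). Compound 3 is therefore expected to give about 78%, within a range from 55% to 98%.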

Compound 3, a percentage reported as activity, at one concentration (the size of the read-out at that concentration, not a potency): 61.6%
Estimate against measurement, compound 3: 16.4 percentage points above, within the range that was stated.
By their numbers in this assay, from the lowest: compounds 2 and 3 (each within the scatter of the next); then compound 1.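

In this assay replacing the hexyl on the triple-bonded carbon with the silicon-bearing group of 4 heavy atoms gives a number 4.7 percentage points higher from compound 2 to compound 3 (within the scatter) and so does not separate the two groups. At this place, then, an all-carbon chain is not required for the effect seen with compound 2, since a group with fewer heavy atoms that includes silicon gives a read-out that cannot be told apart from it. The compounds shown offer no measurement that explains this similarity.

On these data alone, it remains open how far this tolerance extends: a plain methyl, or a chain longer than hexyl, might keep the read-out or shift it. The same holds for a chain ending in an amine or a carboxylic acid.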